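The compounds below may be only part of what the source reports. "The series", "measured", "known", "first", "only" and "open" are said of these compounds alone.

Compound 1 `Cc1cc(=O)oc2cc(OCc3cn(-c4ccc(F)c(Cl)c4)nn3)ccc12` was tested in an ADME assay on Huh-7 cells (Homo sapiens) for cytotoxicity, read by MTT assay, with a stated time of 72 h; on this read-out higher numbers stand for lower toxicity in this test and lower numbers for higher toxicity in this test. For compound 1 the value > 100 ug/mL is a limit of the assay, not a number. Compound 2 `Cc1cc(=O)oc2cc(OCc3cn(-c4ccccc4Cl)nn3)ccc12` likewise gives only a limit, > 100 ug/mL. Compound 3 `Cc1cc(=O)oc2cc(OCc3cn(-c4ccc(F)cc4F)nn3)ccc12` also gives a limit, > 100 ug/mL. All three therefore share (the limit of > 100 ug/mL in this assay, at which 3 of the 3 values shown sit). The swaps of the group on the aromatic nitrogen give a step that the two limits leave unreadable from compound 1 to compound 2, a step that the two limits leave unreadable from compound 1 to compound 3 and a step that the two limits leave unreadable from compound 2 to compound 3, so none of these steps shows a readable size. Compound 4 `Cc1cc(=O)oc2cc(OCc3cn(Cc4ccccc4)nn3)ccc12` differs from compound 1 by benzyl in place of 3-chloro-4-fluorophenyl on an aromatic nitrogen. Since every change on the aromatic nitrogen seen so far left the value at the limit, the expected step is a number no higher from compound 1 to compound 4 (the limit leaves the size open), meaning no change beyond the scatter. Compound 4 is therefore estimated at 100 ug/mL, with a range from 40 ug/mL to 250 ug/mL.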

Compound 4, half-maximal cytotoxic concentration: > 100 ug/mL
Compound 4: no number, only a limit; the forecaster's own chance of this, stated with the estimate: 80%; the middle value lies on the limit itself.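

In this assay, for the compounds shown here, no step from compound 1, compound 2 or compound 3 to compound 4 can be read, because all four compounds stop at the same limit: the limit of > 100 ug/mL in this assay, at which 4 of the 4 values shown sit. From the compounds shown here alone, whether the group on the aromatic nitrogen changes toxicity in this test at all stays open, as does how far past the limit each compound's true value lies.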